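Moving a methyl on the anilino ring of compound 2

This account rests on a few compounds, and the source may have more. Where it says the series, first, only, none or still open, it means among the compounds named here.

Measured compounds:
compound 1, `Cc1cc(F)cc(Nc2cc(NC(=O)Nc3c(Cl)cccc3Cl)ncn2)c1`: 78.1%
compound 2, `COc1cc(NC(=O)Nc2cc(Nc3ccc(C)c(F)c3)ncn2)cc(OC)c1`: 39.7%

In a functional assay on NCI-H226 cells (Homo sapiens) for inhibition, read by MTT assay, with a stated time of 48 h, tested at 10 uM (a higher number here means more inhibition at the concentration tested (going by the name of the read-out), a lower number less inhibition), compound 1 gives 78.1%. In this assay compound 2 gives 39.7%, the lower of the two numbers, and compound 1 stands above it by a gap that lies beyond the usual scatter. The two differ in more than one place, so their values are compared only as they stand.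

Compound 3, `COc1cc(NC(=O)Nc2cc(Nc3cc(C)cc(F)c3)ncn2)cc(OC)c1`, has not yet been measured in this assay. It keeps the whole of compound 2 except for one change: 3-fluoro-5-methylphenyl in place of 3-fluoro-4-methylphenyl on a nitrogen on an aromatic ring. The same atoms are present, joined differently. Going by the values given here, no measured pair shows what such a rearrangement does here, so the step is expected to be small, in either direction or none beyond the scatter. The estimated step is a number 0.3 percentage points higher from compound 2 to compound 3 (within the scatter). Compound 3 is therefore expected to give 40%, in a range from 24% to 56%.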

Compound 3, a percentage reported as inhibition, at one concentration (the size of the read-out at that concentration, not a potency): 35.3%
Beside the measured number, compound 3's estimate is 4.7 percentage points above it; low and high end bracket the measured number.
By their numbers in this assay, from the lowest: compounds 3 and 2 (each within the scatter of the next); then compound 1.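

Going by these compounds alone, the change from 3-fluoro-4-methylphenyl to 3-fluoro-5-methylphenyl gives the first single-place step, a number 4.4 percentage points lower from compound 2 to compound 3 (within the scatter) in this assay. On a nitrogen on an aromatic ring, then, these two arrangements of the same atoms cannot be told apart in this read-out at the concentration tested. No measurement shown here accounts for this result.

As far as these compounds go, it remains open whether another group in place of the methyl, such as a methoxy, an amine or a carboxylic acid, would produce a step beyond the scatter. Within the data shown here, also open is which of the several places separating compound 2 from compound 1 goes with the value of compound 1, 78.1%, as no single-place step connects them.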